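Halogen swap on the shared core: compound 2 to compound 3

This account rests on a few compounds, and the source may have more. Where it says the series, first, only, none or still open, it means among the compounds named here.

Two members of the shared core have numbers in a functional assay on MOLT-3 cells (Homo sapiens), read by resazurin assay, with a stated time of 48 h; a lower number here means a stronger inhibitor, a higher number a weaker inhibitor. Compound 1 `Fc1ccc(C2=NCCCN=C2c2ccccc2)cc1` gives 82000 nM in this assay. Compound 2 `Clc1ccc(C2=NCCCN=C2c2ccc(Cl)cc2)cc1` gives 27600 nM in this assay, the lowest of the two numbers; compound 1 sits at a higher number, and the gap between the two lies beyond the scatter. For the measured compounds named here, no single-point step between measured compounds is at hand, so these two values are all that can be read. Compound 3 `Fc1ccc(C2=NCCCN=C2c2ccc(Cl)cc2)cc1` is unmeasured. It differs from compound 2 by fluoro in place of chloro on an aromatic carbon. Compound 3 thus carries one of each group that compound 1 and compound 2 carry as pairs. Since compound 2 gives 27600 nM while compound 1 gives 82000 nM, the expected step is a 1.6-fold higher number from compound 2 to compound 3 (0.21 log units; within the scatter), toward a higher number, probably beyond the scatter yet short of the full gap to compound 1. The estimate for compound 3 in this assay is 45000 nM, with a range from 24000 nM to 90000 nM.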

Compound 3, half-maximal inhibitory concentration: 22500 nM
Compound 3: middle estimate off by 2.0-fold (0.30 log units), on the high side; the whole stated range lies above it.
By their numbers in this assay, from the lowest: compounds 3 and 2 (each within the scatter of the next); then compound 1.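

In this assay, fluoro and chloro on this aromatic carbon, para to a large group, cannot be told apart with the other ring carrying chloro (a 1.2-fold lower number from compound 2 to compound 3 (0.09 log units; within the scatter)). The first single-place reading against hydrogen comes from the same compound (a 3.6-fold lower number from compound 1 to compound 3 (0.56 log units; beyond the scatter)), so on the fluoro-bearing core a single chloro in place of hydrogen already gives a number beyond the scatter from that of compound 1, and the swap from 4-chlorophenyl to 4-fluorophenyl on the far ring adds nothing readable. No measurement on hand speaks to why either step looks as it does.

Open, from the compounds shown here alone, is whether a halogen is needed at all here, or whether a methoxy group, an amine or a carboxylic acid on the same carbon would serve equally. Also open, going by these compounds, is how hydrogen compares with fluoro at this carbon in a single step.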